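Removing One Hydroxy from a Catechol Compound Measured Against Alpha Glucosidase

A few compounds are considered here, and "the series" means these few. Any claim that something is new, unique, unknown or untested is made for them only; others in the source may bear on it.

Compound 1 `O=C(C1=C(O)/C(=C/c2ccc(O)c(O)c2)CCC1)c1ccccc1`: 55.9%
Compound 2 `COc1cc(/C=C2\CCC/C(=C\c3ccccc3)C2=O)cc(OC)c1OC`: 16.3%

In an assay on isolated protein for inhibition of Alpha glucosidase (Homo sapiens), with stated times of 5 min and 15 min, tested at 50 uM (on this read-out higher numbers stand for more inhibition at the one concentration tested (going by the name of the read-out) and lower numbers for less inhibition), compound 1 gives 55.9%, the highest of the two numbers measured. Compound 2 gives 16.3%, lower by a margin beyond the usual scatter. Among the compounds with values here, the two measured compounds differ in more than one place, so no single step between them can be read.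

Compound 3 `O=C(C1=C(O)/C(=C/c2ccc(O)cc2)CCC1)c1ccccc1` is not yet measured. Relative to compound 1 the change is hydrogen in place of hydroxy on an aromatic carbon. Within the data shown here, the only guidance is that compound 2, which carries no free hydroxy at all, gives 16.3% in this assay. Compound 3 is therefore expected to fall below compound 1, by a step of a number 20.9 percentage points lower from compound 1 to compound 3 (beyond the scatter), a loss beyond the scatter but smaller than the gap to compound 2. The estimate for compound 3 in this assay is 35%, with a range from 15% to 55%.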

Compound 3, a percentage reported as inhibition, at one concentration (the size of the read-out at that concentration, not a potency): 34.9%
Compound 3: the middle estimate sits 0.1 percentage points above what was measured; low and high end bracket the measured number.
By their numbers in this assay, from the lowest: compound 2; then compound 3; then compound 1.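

In this assay, within the data shown here, the change from 3,4-dihydroxyphenyl to 4-hydroxyphenyl gives a number 21 percentage points lower from compound 1 to compound 3 (beyond the scatter) and is the first reading in this set that can be tied to one place in the structure. It shows that the hydroxy on this aromatic carbon, ortho to a hydroxy group, contributes to the inhibition seen, yet its removal does not abolish it: compound 3 still gives 34.9% in this read-out. The data offer no measured explanation for the loss at this position.

As far as these compounds go, whether the remaining hydroxy on the ring of compound 3 counts for as much stays open. So does whether an amine or a carboxylic acid on the same aromatic carbon would recover, or further lower, the number seen for compound 1 with its hydroxy there.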